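The source may hold more compounds than are shown below. What is called first, only, known or untested is meant among the compounds shown, and "the series" means these compounds.

Measured compounds in a functional assay on MDA-MB-231 cells (Homo sapiens) for antiproliferative activity, read by sulforhodamine B assay; a higher number here means a weaker inhibitor of growth, a lower number a stronger inhibitor of growth:

compound 1 `O=C(/C=C/c1ccc(O)cc1)c1c(O)cccc1OCc1ccccc1` — compound 1 gives > 30000 nM.
compound 2 `CC(C)(C)CCOc1cccc(O)c1C(=O)CCc1ccc(O)cc1` — compound 2 gives > 30000 nM.

For compound 1 the reading > 30000 nM is a limit of the assay, not a number. For compound 2 the reading > 30000 nM is likewise a limit. Within the data shown here, compound 1 therefore stands where everything measured here stands, at the limit of > 30000 nM in this assay, at which 2 of the 2 values shown sit, and no measured pair differs in only one place, so no step size can be read from the data. Compound 3 `CC(C)CCOc1cccc(O)c1C(=O)/C=C/c1ccc(O)cc1` is still to be measured in this assay. It differs from compound 1 in one place: isobutyl in place of phenyl on a saturated chain carbon bound to an oxygen on an aromatic ring. Because both known readings sit at the limit of > 30000 nM in this assay, at which 2 of the 2 values shown sit, no step beyond the usual scatter is expected in either direction. The step of a number no higher from compound 1 to compound 3 (the limit leaves the size open) is expected to be small. Compound 3 is expected to give roughly 30000 nM, somewhere between 8000 nM and 100000 nM, and most likely to be reported again only as a limit.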

Compound 3, concentration for 50% growth inhibition: 10300 nM
The estimate for compound 3 lay 2.9-fold (0.46 log units) above the measured number; the measured number falls inside the stated range.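

In this assay, compound 3 is the first compound shown to give a true number rather than a limit, which sets it apart from the earlier readings: the limit of > 30000 nM in this assay, at which 2 of the 3 values shown sit.

The group on the saturated chain carbon bound to an oxygen on an aromatic ring therefore affects growth inhibition, with isobutyl in place of phenyl giving an at least 2.9-fold lower number from compound 1 to compound 3 (0.46 log units; beyond the scatter). The reading for compound 1 is only a limit, so the true step could be larger, but an aromatic ring is clearly not required at this place.

From the compounds shown here alone, whether a longer chain, or an amine at the end of the chain, would strengthen growth inhibition further remains open. Compound 2 differs from compound 3 in more than one place, so no further step can be read.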